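The compounds below may be only part of what the source reports. "The series", "measured", "known", "first", "only" and "open" are said of these compounds alone.

Working notes on the shared core. Compound 1 `COC(=O)c1ccc(NCc2cncn2Cc2cccc([N+](=O)[O-])c2)cc1-c1ccccc1` carries 3-nitrophenyl on a saturated chain carbon bound to an aromatic nitrogen. In a toxicity assay on NIH3T3 cells (Mus musculus) for cytotoxicity, read by resazurin assay (on this read-out lower numbers stand for an effect already at smaller amounts and higher numbers for an effect only at larger amounts of compound), compound 1 gives only a limit, > 10000 nM. Compound 2 `COC(=O)c1ccc(NCc2cncn2Cc2ccc([N+](=O)[O-])cc2)cc1-c1ccccc1` has 4-nitrophenyl in place of 3-nitrophenyl on a saturated chain carbon bound to an aromatic nitrogen. In this assay compound 2 likewise reaches only a limit, > 10000 nM. Compound 3 `COC(=O)c1ccc(NCc2cncn2Cc2cccc(N)c2)cc1-c1ccccc1` carries amino in place of nitro on an aromatic carbon. In this assay compound 3 also stops at a limit, > 10000 nM. Every step among the three is unreadable, namely a step that the two limits leave unreadable from compound 1 to compound 2, a step that the two limits leave unreadable from compound 1 to compound 3 and a step that the two limits leave unreadable from compound 2 to compound 3, because of the limit of > 10000 nM in this assay, at which 3 of the 3 values shown sit. Compound 3 therefore stands nowhere apart from compound 1 or compound 2; all three share the same limit.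

Compound 4 `COC(=O)c1ccc(NCc2cncn2Cc2cccc(C#N)c2)cc1-c1ccccc1` brings the next change: cyano in place of amino on an aromatic carbon. Going by the values given here, none of the three measured steps bears readably on it, since no step has a size. With nothing to set it apart, compound 4 is expected to stay at the limit as well, the expected step being a step that the limit leaves unreadable from compound 3 to compound 4. The estimate for compound 4 in this assay is 25000 nM, with a range from 8000 nM to 100000 nM.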

Compound 4, half-maximal effective concentration: > 10000 nM
Compound 4: no number, only a limit; the forecaster's own chance of this, stated with the estimate: 85%; the middle value does not contradict the limit.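

No step from compound 1, compound 2 or compound 3 to compound 4 can be read, because all four compounds end at one limit: the limit of > 10000 nM in this assay, at which 4 of the 4 values shown sit.

The compounds shown leave open whether nitro, amino and cyano differ at all in this assay, as none of the four gives a number.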